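Aryl-hydrazone-carbonyl series: moving the benzodioxin attachment point

The compounds below may be only part of what the source reports. "The series", "measured", "known", "first", "only" and "open" are said of these compounds alone.

Measured compounds:
- compound 1, `COc1ccc(C2=NN(C(=O)c3ccc4c(c3)OCCO4)C(c3ccc(F)cc3)C2)cc1`, 3780 nM
- compound 2, `O=C(c1ccc2c(c1)OCCO2)N1N=C(c2ccccc2)CC1c1ccc(F)cc1`, 5210 nM
- compound 3, `O=C(C1COc2ccccc2O1)N1N=C(c2ccc(Br)cc2)CC1c1ccc(F)cc1`, 5630 nM

All three were read in a functional assay on WM 266-4 cells (Homo sapiens) for inhibition, read by MTT assay, with a stated time of 24 h; on this read-out lower numbers stand for stronger inhibition of growth and higher numbers for weaker inhibition of growth. Compound 3 stands at the highest of the three numbers; compound 2 is the nearest to it and compound 1 the furthest, and both gaps are within the scatter, so no order among the three can be claimed. Within the data shown here, the one single-point step measured so far, a 1.4-fold higher number from compound 1 to compound 2 (0.14 log units; within the scatter), is also within the scatter.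

Compound 4, `O=C(c1ccc2c(c1)OCCO2)N1N=C(c2ccc(Br)cc2)CC1c1ccc(F)cc1`, has not yet been measured. It differs from compound 3 by 2,3-dihydro-1,4-benzodioxin-6-yl in place of 2,3-dihydro-1,4-benzodioxin-2-yl on a carbonyl carbon. Among the measured compounds shown here, compound 2 carries the same entering group on its carbonyl carbon, but no measured step concerns this attachment change, and the step from compound 1 to compound 2 concerns a different part of the molecule, so it gives no guidance here. With nothing in the data pointing either way, the expectation for compound 4 in this assay is a step of a 1.1-fold lower number from compound 3 to compound 4 (0.05 log units; within the scatter), that is, none beyond the scatter. Compound 4 is therefore estimated at 5000 nM, expected between 2500 nM and 10000 nM.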

Compound 4, concentration for 50% growth inhibition: 3260 nM
For compound 4 the middle estimate is 1.5-fold (0.19 log units) above the measured one; the range from low to high includes it.
By their numbers in this assay, from the lowest: compounds 4, 1, 2 and 3 (each within the scatter of the next).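

In this assay, among these compounds, 2,3-dihydro-1,4-benzodioxin-6-yl in place of 2,3-dihydro-1,4-benzodioxin-2-yl on the carbonyl carbon gives a 1.7-fold lower number from compound 3 to compound 4 (0.24 log units; within the scatter) and so adds a first reading of this attachment change, which stays within the scatter in the bromo pair. On the aromatic carbon, bromo in place of hydrogen gives a 1.6-fold lower number from compound 2 to compound 4 (0.20 log units; within the scatter) and bromo in place of methoxy gives a 1.2-fold lower number from compound 1 to compound 4 (0.06 log units; within the scatter) so that hydrogen, methoxy and bromo show no separation beyond the scatter at this place. Nothing available bears on these results.

The compounds shown leave open whether the attachment change reads the same with hydrogen or methoxy on that aromatic carbon. They also leave open whether an amine or a carboxylic acid there would give a step beyond the scatter.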